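Phenyl for methyl on the piperazine nitrogen of compound 3

This account rests on a few compounds, and the source may have more. Where it says the series, first, only, none or still open, it means among the compounds named here.

Three members of the series have numbers in an assay on isolated protein for inhibition of Thymidylate synthase (Homo sapiens); a lower number here means a stronger inhibitor, a higher number a weaker inhibitor. Compound 3 `CN1CCN(C(=O)Cn2c(-c3ccccc3)csc2=N)CC1` gives 1140 nM, the lowest of the three. Compound 1 `Cc1ccc(-c2csc(=N)n2CC(=O)N2CCN(c3ccccc3)CC2)cc1` gives 5600 nM and compound 2 `N=c1scc(-c2ccccc2)n1CC(=O)N1CCOCC1` gives 6220 nM; both sit well above compound 3. For the measured compounds named here, the one single-point step within the measured set is a 5.5-fold lower number from compound 2 to compound 3 (0.74 log units; beyond the scatter).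

Compound 4 `N=c1scc(-c2ccccc2)n1CC(=O)N1CCN(c2ccccc2)CC1` differs from compound 3 in one place: phenyl in place of methyl on an amine nitrogen in a ring. Going by the values given here, no measured step matches this change directly. The step from compound 2 to compound 3 concerns the same ring position but a different exchange and so bears only loosely. Compound 1 carries the same phenyl-bearing piperazine as compound 4, though with a different aryl on the shared core, and its number in this assay is close to that of compound 2, well above compound 3. On that basis a move back towards the weaker end of the series is expected for compound 4, a step of about a 3.5-fold higher number from compound 3 to compound 4 (0.55 log units; beyond the scatter) in this assay.

Compound 4 is therefore estimated at 4000 nM in this assay, with a range from 1500 nM to 10000 nM.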

Compound 4, inhibition constant: 1360 nM
Compound 4: the middle estimate sits 2.9-fold (0.47 log units) above what was measured; the whole stated range lies above it.
By their numbers in this assay, from the lowest: compounds 3 and 4 (each within the scatter of the next); then compounds 1 and 2 (each within the scatter of the next).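

In this assay, phenyl in place of methyl on the amine nitrogen in the ring gives a 1.2-fold higher number from compound 3 to compound 4 (0.08 log units; within the scatter), so this position accepts a six-membered aromatic ring of carbon in place of a single carbon with no change beyond the scatter. The higher number of compound 1 therefore does not go with the phenyl on this nitrogen: hydrogen in place of methyl on an aromatic carbon gives a 4.1-fold lower number from compound 1 to compound 4 (0.61 log units; beyond the scatter), and in this pair it is that one place on the aryl group, not the phenyl, that separates the two numbers. The data shown offer no measured explanation for either step.

As far as these compounds go, only methyl and phenyl have been compared on this nitrogen, so it remains open whether a benzyl group, a longer alkyl chain or a chain ending in a carboxylic acid would also leave the number unchanged. The methyl on the aromatic carbon is likewise a single case, and the compounds shown do not say whether a chlorine or a methoxy group in its place would give a step of similar size.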